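The compounds below may be only part of what the source reports. "The series", "measured", "known", "first", "only" and "open" are said of these compounds alone.

In a functional assay on SGC-7901 cells (Homo sapiens) for inhibition, read by MTT assay, with a stated time of 48 h (on this read-out higher numbers stand for weaker inhibition and lower numbers for stronger inhibition), compound 1 `Cc1nnsc1CO/N=C/c1c(C)nn(C)c1Oc1ccc(F)cc1` reports only a limit, > 50000 nM. Compound 2 `Cc1nnsc1CO/N=C/c1c(C)nn(C)c1Oc1ccc(I)cc1` also reports only a limit, > 50000 nM. Among the measured compounds shown here, compound 3 `Cc1nnsc1CO/N=C/c1c(C)nn(C)c1Oc1cccc(F)c1F` gives 25700 nM, the only actual number among the three. Compound 4 `Cc1nnsc1CO/N=C/c1c(C)nn(C)c1Oc1cc(F)cc(F)c1` differs from compound 3 in one place, with 3,5-difluorophenyl in place of 2,3-difluorophenyl on an oxygen on an aromatic ring. The measured steps that bear on this change are an at least 1.9-fold lower number from compound 1 to compound 3 (0.28 log units; that floor lies within the scatter) and an at least 1.9-fold lower number from compound 2 to compound 3 (0.28 log units; that floor lies within the scatter). Both altered the same group, and neither is shown to lie beyond the scatter. No step beyond the scatter is therefore expected in this assay. The expected step is a 1.2-fold higher number from compound 3 to compound 4 (0.07 log units; within the scatter). Compound 4 is expected at 30000 nM, with an estimated range of 13000 nM to 60000 nM.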

Compound 4, half-maximal inhibitory concentration: 9410 nM
Beside the measured number, compound 4's estimate is 3.2-fold (0.50 log units) above it; measured number below the stated range.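

In this assay, rearranging the two fluorines from 2,3-difluorophenyl to 3,5-difluorophenyl, with the atoms unchanged, gives a 2.7-fold lower number from compound 3 to compound 4 (0.44 log units; beyond the scatter), so their arrangement alone moves the number at this place beyond the scatter. The steps to compound 4 from the two singly substituted phenyl groups, an at least 5.3-fold lower number from compound 2 to compound 4 (0.72 log units; beyond the scatter) and an at least 5.3-fold lower number from compound 1 to compound 4 (0.72 log units; beyond the scatter), also clear the scatter, which the steps to compound 3 did not. Both are floors set by a limit of the assay: the limit of > 50000 nM in this assay, at which 2 of the 4 values shown sit. On these data alone, whether a 3,5-dichlorophenyl or 3,5-dimethoxyphenyl group at this place would give a lower number stays open. As far as these compounds go, the true size of those two floors also stays open.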